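A few compounds are considered here, and "the series" means these few. Any claim that something is new, unique, unknown or untested is made for them only; others in the source may bear on it.

Working notes on the series. Of the compounds shown here, three have been measured in a functional assay on the whole organism for inhibition, with Rattus norvegicus as the target, read by paw edema, with a stated time of 30 min, at a dose of 20 mg/kg by the oral route; on this read-out higher numbers stand for a stronger effect at the one dose given and lower numbers for a weaker effect. Compound 3 `O=[N+]([O-])c1ccc(OCC2=NCCO2)cc1` gives 29.2%. Compound 2 `O=[N+]([O-])c1ccccc1OCC1=NCCO1` gives 20.5%. Compound 1 `Fc1ccc(OCC2=NCCO2)cc1` gives 18.5%. Compound 2 and compound 3 are built from the same atoms joined differently; the difference between the two cores is not broken down here. The values of compound 2 and compound 1 lie within the scatter of each other, so that pair carries no reading.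

One step is measured: a number 10.7 percentage points lower from compound 3 to compound 1 (beyond the scatter). The change behind it is fluoro in place of nitro on an aromatic carbon Compound 4 `Fc1ccccc1OCC1=NCCO1` is not yet measured. It arises from compound 2 by fluoro in place of nitro on an aromatic carbon This is the same kind of change as the measured one, not the same change: in compound 3 the place is para to a group of 7 heavy atoms, whereas in compound 2 it is ortho to a group of 7 heavy atoms. The expectation for compound 4 in this assay rests on a single earlier instance. For compound 4 the expected step is a number 9.5 percentage points lower from compound 2 to compound 4 (within the scatter), because the step of a number 10.7 percentage points lower from compound 3 to compound 1 (beyond the scatter) was modest and downward. Compound 4 is accordingly estimated at 11%, expected to fall between 3% and 20%.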

Compound 4, a percentage reported as inhibition, in the whole organism at one dose (the size of the read-out at that dose, not a potency): 20.6%
Beside the measured number, compound 4's estimate is 9.6 percentage points below it; the whole stated range lies below it.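

In this assay the new step reads a number 0.1 percentage points higher from compound 2 to compound 4 (within the scatter), so fluoro in place of nitro gives no readable difference on the core of compound 2. The two instances of the change cannot be told apart: the same change on two cores in this assay, a number 10.7 percentage points lower (beyond the scatter) from compound 3 to compound 1 and a number 0.1 percentage points higher (within the scatter) from compound 2 to compound 4, 10.8 percentage points apart, within the scatter of two such steps

Going by these compounds, this does not show that the change carries from one core to the other with the same size, since one step lies beyond the scatter and the other within it, and it does not show that the outcome depends on the core or on the place of the group; with one instance on each core, both readings stay open.

The compounds shown leave open how an amine, a carboxylic acid or a methoxy group would read in place of nitro or fluoro on the aromatic ring, and how a longer chain would read in place of the link to the shared ring. On these data alone, each reading also stands at a single dose, so how these compounds would rank across doses remains open.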